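The source may hold more compounds than are shown below. What is called first, only, known or untested is meant among the compounds shown, and "the series" means these compounds.

Of the compounds shown here, three have so far been tested in a functional assay on DU-145 cells (Homo sapiens) for inhibition, read by trypan blue exclusion, with a stated time of 72 h; on this read-out lower numbers stand for stronger inhibition and higher numbers for weaker inhibition. Compound 1, `COc1ccc(Nc2ncc3cc(S(=O)(=O)c4ccc(C)cc4)c(=O)n(C)c3n2)cc1`, gives 100000 nM. Compound 2, `Cn1c(=O)c(S(=O)(=O)Cc2ccc(F)cc2F)cc2cnc(Nc3ccc4[nH]ccc4c3)nc21`, gives 1000 nM. Compound 3, `Cn1c(=O)c(S(=O)(=O)c2ccc(F)cc2F)cc2cnc(Nc3ccncn3)nc21`, gives 50000 nM, the second highest of the three numbers; its nearest neighbour is compound 1, whose number lies within the scatter of that of compound 3, so no order between these two can be read, while compound 2 stands far lower, well beyond the scatter.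

The step followed here leads from compound 3 to compound 4, `Cc1cc2cc(Nc3ncc4cc(S(=O)(=O)c5ccc(F)cc5F)c(=O)n(C)c4n3)ccc2[nH]1`, which has not yet been measured in this assay. The change is 2-methyl-1H-indol-5-yl in place of pyrimidin-4-yl on a nitrogen on an aromatic ring. Among the measured compounds, compound 2 carries a closely related group on the same nitrogen and is the only one with a low number, giving 1000 nM, whereas compound 3 and compound 1 carry other groups there and both give high numbers. On that basis a large step down in this assay, well beyond the scatter, is expected, a 25-fold lower number from compound 3 to compound 4 (1.40 log units; beyond the scatter). Compound 4 is therefore estimated at 2000 nM, with a range from 500 nM to 8000 nM, the width of the range allowing for the other differences between compound 2 and compound 4.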

Compound 4, half-maximal inhibitory concentration: 750 nM
For compound 4 the middle estimate is 2.7-fold (0.43 log units) above the measured one, within the range that was stated.
By their numbers in this assay, from the lowest: compounds 4 and 2 (each within the scatter of the next); then compounds 3 and 1 (each within the scatter of the next).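

Within the data shown here, compound 3 and compound 4 differ in one place only, so this pair isolates the group on the nitrogen on an aromatic ring, which the earlier compounds, all differing in more than one place, could not do. In this assay, replacing pyrimidin-4-yl with 2-methyl-1H-indol-5-yl on that nitrogen gives a 67-fold lower number from compound 3 to compound 4 (1.82 log units; beyond the scatter), showing that this position alone can carry a large change in the read-out with the rest of the molecule held constant. The change brings several differences at once, a larger fused pair of aromatic rings, a hydrogen-bond donor and the loss of the two hydrogen-bond acceptors, and no available evidence bears on the reason for the step.

The compounds shown leave open which of these differences accounts for the step, including what the 2-methyl group and the indole hydrogen each contribute. From the compounds shown here alone, it also remains open whether a plain phenyl or a quinolinyl group on the same nitrogen would give a number closer to that of compound 3 or that of compound 4, and whether the step would hold with another group on the sulfonyl.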